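The source may report more compounds than this note shows. Statements on the series, on what has been measured and on what is new or still open speak of the compounds shown alone.

Among the measured compounds shown here, compound 3 `NNC(=O)COc1ccncc1-c1ccc2ccccc2c1` stands second highest of the three numbers so far. In an assay on a protein complex for inhibition of CDK8/Cyclin C (Homo sapiens), with a stated time of 1 h, tested at 10 uM (on this read-out lower numbers stand for less inhibition and higher numbers for more inhibition at the one concentration tested (going by the name of the read-out)), compound 3 gives 19%. For the measured compounds named here, compound 1 `CNC(=O)/C=C/c1ccncc1-c1ccc2ccccc2c1` gives 101% in this assay, and the step of a number 82 percentage points lower from compound 1 to compound 3 (beyond the scatter) is the one large change in the set. Compound 2 `O=C(COc1ccncc1-c1ccc2ccccc2c1)N1CCOCC1` gives 9% in this assay; the step of a number 10 percentage points higher from compound 2 to compound 3 (within the scatter) stays within the scatter, so compound 2 and compound 3 cannot be separated on these numbers.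

Compound 4 `O=C(O)COc1ccncc1-c1ccc2ccccc2c1` differs from compound 3 only at the carbonyl carbon: hydroxy in place of aminoamino on a carbonyl carbon. The measured step that bears on this also exchanges the group on that carbonyl carbon while keeping the rest of the molecule unchanged: a number 10 percentage points higher from compound 2 to compound 3 (within the scatter), within the scatter. The step of a number 82 percentage points lower from compound 1 to compound 3 (beyond the scatter) alters the chain that joins the carbonyl to the aromatic carbon and therefore says little about a change confined to the carbonyl carbon. Since two different groups on this carbonyl carbon gave numbers within the scatter of each other, no step beyond the scatter is expected in this assay for hydroxy either. Compound 4 is expected to give 15% in this assay, with a range from 2% to 35%. The step this estimate means, a number 4 percentage points lower from compound 3 to compound 4 (within the scatter), is expected to stay within the scatter.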

Compound 4, a percentage reported as inhibition, at one concentration (the size of the read-out at that concentration, not a potency): 16%
The estimate for compound 4 lay 1 percentage points below the measured number; low and high end bracket the measured number.
By their numbers in this assay, from the lowest: compounds 2, 4 and 3 (each within the scatter of the next); then compound 1.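

In this assay, hydroxy on the carbonyl carbon now stands with aminoamino and morpholin-4-yl: a number 3 percentage points lower from compound 3 to compound 4 (within the scatter) and a number 7 percentage points higher from compound 2 to compound 4 (within the scatter) show that none of the three groups can be separated from the others on this chain, so the exchange at this carbonyl carbon has produced no step beyond the scatter in compounds 2, 3 and 4. The other comparison, a number 85 percentage points lower from compound 1 to compound 4 (beyond the scatter), shows that the large step away from 2-(methylcarbamoyl)ethenyl recurs with carboxymethoxy as it did with (aminocarbamoyl)methoxy, so it does not depend on which of these two groups ends the oxygen-linked chain. Nothing available explains either the flat response at the carbonyl carbon or the large step from compound 1.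

As far as these compounds go, it remains open whether the large step follows from the oxygen link, the loss of the carbon-carbon double bond or the group on the carbonyl, and a methylamino group on the carbonyl carbon of the carboxymethoxy chain would bear directly on the last of these. A longer chain carrying a carboxylic acid or an amine at its end is also untested ground in what is shown here.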